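Working notes on the series: estimate for compound 4

This account rests on a few compounds, and the source may have more. Where it says the series, first, only, none or still open, it means among the compounds named here.

The read-out throughout is a functional assay on the whole organism (strain NMRI) with Mus musculus as the target, with a stated time of 5 min; on this read-out lower numbers stand for an effect already at smaller amounts and higher numbers for an effect only at larger amounts of compound. Compound 1 `CCC1(CCCCN2CCN(c3ccc(C)c(Cl)c3)CC2)C(=O)Nc2ccccc21` has no result in this assay: its entry reads "not determined" (no result reported). Compound 2 `O=C1Nc2ccc(F)cc2C1CCCCN1CCN(c2ccc(F)cc2)CC1` likewise shows "not determined" (no result reported) in this assay. Compound 3 `CCC1(CCCCCN2CCN(c3cccc(Cl)c3)CC2)C(=O)Nc2ccccc21` is reported only as a limit of this assay, > 10 mg/kg. So among the three entries, compound 1 has no single number, one further value is a limit, and one further entry carries no number at all; the only fixed point is the limit of > 10 mg/kg in this assay, at which 1 of the 3 values shown sits, where one of the three values sits.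

Compound 4 `CCC1(CCCCN2CCN(c3ccc(Cl)cc3)CC2)C(=O)Nc2ccccc21` differs from compound 1 by 4-chlorophenyl in place of 3-chloro-4-methylphenyl on an amine nitrogen in a ring. Going by the values given here, no step between measured compounds exists against which this change can be sized. In this assay no direction is therefore claimed for the move from compound 1 to compound 4, and a step of no size beyond the usual scatter is the expectation, though compound 1 itself gives no number to anchor it.

Taking the limit of compound 3 as the only measured reference, the minimum effective dose of compound 4 in this assay is estimated at 12 mg/kg, with a range from 3 mg/kg to 50 mg/kg, and a sizeable chance that only a limit is reported.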

Compound 4, minimum effective dose: > 10 mg/kg
Compound 4 gave a limit, no number; the forecaster's own chance of this, stated with the estimate: 45%; the middle value does not contradict the limit.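

Going by these compounds alone, compound 1 has no single number in this assay, so no step to compound 4 can be read. Compound 4 gives > 10 mg/kg, which is a limit and not a number. The compounds shown leave open whether 4-chlorophenyl in place of 3-chloro-4-methylphenyl shifts the minimum effective dose in this assay, in either direction.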